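A few compounds are considered here, and "the series" means these few. Any claim that something is new, unique, unknown or untested is made for them only; others in the source may bear on it.

Measured in a functional assay on MG-63 cells (Homo sapiens) for cytotoxicity, read by MTT assay; a higher number here means a weaker inhibitor, a lower number a stronger inhibitor:
compound 1 `C=C1[C@H](OC(C)=O)C[C@H](OC(C)=O)[C@@]2(C)[C@@H](OC(C)=O)C[C@@H](OC(C)=O)[C@]3(CO3)[C@@H]2[C@H](OC(C)=O)[C@]2(O)[C@@H](C)C(=O)O[C@H]2[C@H]1Cl`: 20500 nM
compound 2 `C=C1[C@H](OC(C)=O)C[C@H](OC(C)=O)[C@@]2(C)[C@@H](OC(=O)CC(C)C)C[C@@H](OC(C)=O)[C@]3(CO3)[C@@H]2[C@H](OC(C)=O)[C@]2(O)[C@@H](C)C(=O)O[C@H]2[C@H]1Cl`: 15100 nM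
compound 3 `C=C1[C@H](OC(=O)CC(C)C)C[C@H](OC(C)=O)[C@@]2(C)[C@@H](OC(C)=O)[C@@H](OC(=O)CC(C)C)[C@@H](OC(C)=O)[C@]3(CO3)[C@@H]2[C@H](OC(C)=O)[C@]2(O)[C@@H](C)C(=O)O[C@H]2[C@H]1Cl`: 17400 nM

The three values are not separated. Compound 1 gives 20500 nM and lies within the scatter of both other compounds, so it stands level with them in this assay.

Compound 4 `C=C1[C@H](OC(C)=O)C[C@H](OC(C)=O)[C@@]2(C)[C@@H](OC(C)=O)C[C@@H](OC(=O)CC(C)C)[C@]3(CO3)[C@@H]2[C@H](OC(C)=O)[C@]2(O)[C@@H](C)C(=O)O[C@H]2[C@H]1Cl` is the next case. Its change from compound 1 is isopropyl in place of hydrogen on a saturated chain carbon bound to a carbonyl carbon. The same difference, cut one bond further out, reads acetoxy to (isobutylcarbonyl)oxy.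

Among the measured compounds shown here, one measured step bears directly on this: a 1.4-fold lower number from compound 1 to compound 2 (0.13 log units; within the scatter). It is the same exchange made at a different place on the shared core, and it stays within the scatter. Compound 3 differs from compound 1 in more than one place, so it offers only indirect support, but compound 3 gives 17400 nM, also within the scatter of compound 1.

No shift beyond the scatter is therefore expected in this assay. The expected step is a 1.2-fold lower number from compound 1 to compound 4 (0.08 log units; within the scatter).

The estimate for compound 4 is 17000 nM, with an expected range of 10000 nM to 29000 nM.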

Compound 4, half-maximal inhibitory concentration: 18000 nM
Beside the measured number, compound 4's estimate is 1.1-fold (0.02 log units) below it; the measured number falls inside the stated range.
By their numbers in this assay, from the lowest: compounds 2, 3, 4 and 1 (each within the scatter of the next).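

In this assay, the exchange of acetoxy to (isobutylcarbonyl)oxy at this second place on the shared core gives a 1.1-fold lower number from compound 1 to compound 4 (0.06 log units; within the scatter), so the step stays within the scatter here too. Until now a one-place reading of this change existed at a single place only, a 1.4-fold lower number from compound 1 to compound 2 (0.13 log units; within the scatter), and two places now agree in leaving compound 1 unseparated from its isobutyl-bearing counterparts. No available evidence bears on this outcome.

Every one-place exchange shown ends in the same (isobutylcarbonyl)oxy group, so the compounds leave open whether an ester with a longer chain, or one carrying an amine or a carboxylic acid, would move the number beyond the scatter at this place. Going by these compounds, whether a free hydroxyl in place of the acetoxy would do so also remains open.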